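Cytotoxicity notes: bromo for ethoxy on the biaryl series

The compounds below may be only part of what the source reports. "The series", "measured", "known", "first", "only" and "open" are said of these compounds alone.

Compound 1 `CC(C)Oc1cccc(-c2ccc(C(=O)N(Cc3cccc(OCCCCCC(=O)O)c3)C(C)C)cc2)c1`: > 26000 nM (a limit)
Compound 2 `CCOc1cccc(-c2ccc(C(=O)N(Cc3cccc(OCCCCCC(=O)O)c3)C(C)C)cc2)c1`: > 20800 nM (a limit)

In an ADME assay on Raji cells (Homo sapiens) for cytotoxicity, read by CellTiter-Glo and resazurin assay, with a stated time of 72 h (on this read-out higher numbers stand for an effect only at larger amounts of compound and lower numbers for an effect already at smaller amounts), compound 1 gives only a limit, > 26000 nM. Compound 2 likewise gives only a limit, > 20800 nM. The step that the two limits leave unreadable from compound 1 to compound 2 cannot be read from two limits. Compound 2 stands at the limit of > 20800 nM in this assay, at which 1 of the 2 values shown sits. Going by the values given here, the one further value shown is also a limit, (the limit of > 26000 nM in this assay, at which 1 of the 2 values shown sits). Neither value is a number.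

Compound 3 `CC(C)N(Cc1cccc(OCCCCCC(=O)O)c1)C(=O)c1ccc(-c2cccc(Br)c2)cc1` carries bromo in place of ethoxy on an aromatic carbon. No measured step bears on this change: the only step shown, hydrogen in place of methyl, is itself unreadable. With both measured compounds at limits, compound 3 is expected to show no step beyond the scatter, and the estimated step is a step that the limit leaves unreadable from compound 2 to compound 3. Compound 3 is expected to give 25000 nM, within 9000 nM to 70000 nM, most likely again as a limit rather than a number.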

Compound 3, half-maximal effective concentration: > 26000 nM
Compound 3: no number, only a limit; the forecaster's own chance of this, stated with the estimate: 80%; middle value at least 1.0-fold (0.01 log units) from the limit.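

In this assay compound 3 gives > 26000 nM, a limit and not a number. Going by these compounds alone, with compound 1 and compound 2 also at limits, no step to compound 3 can be read. On these data alone, whether bromo, ethoxy and isopropoxy differ at all in this assay stays open.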